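Fluoro to 1H-pyrrol-1-yl on the aromatic carbon

This account rests on a few compounds, and the source may have more. Where it says the series, first, only, none or still open, it means among the compounds named here.

In an ADME assay on HeLa cells (Homo sapiens) for cytotoxicity, read by crystal violet staining, with a stated time of 72 h (a higher number here means that more compound is tolerated, a lower number that less compound is tolerated), compound 1 `CCOC(=O)c1cc(CCCOc2ccc(-c3noc(C(F)(F)F)n3)cc2F)on1` gives 60200 nM and compound 2 `CN(C)C(=O)c1cc(CCCOc2ccc(-c3noc(C(F)(F)F)n3)cc2F)on1` gives 20200 nM, the lower of the two numbers in the series. Compound 3 `CNC(=O)c1cc(CCCOc2ccc(-c3noc(C(F)(F)F)n3)cc2C(F)(F)F)on1` reports only a limit of the assay, > 100000 nM.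

Compound 4 `CN(C)C(=O)c1cc(CCCOc2ccc(-c3noc(C(F)(F)F)n3)cc2-n2cccc2)on1` departs from compound 2 at one place: 1H-pyrrol-1-yl in place of fluoro on an aromatic carbon. The new group, 1H-pyrrol-1-yl, stands in place of fluoro on an aromatic carbon, ortho to a large group.

Within the data shown here, the one measured step, a 3.0-fold lower number from compound 1 to compound 2 (0.47 log units; beyond the scatter), sits at a carbonyl carbon, with dimethylamino in place of ethoxy, and not at the aromatic carbon that changes here. It gives only a rough scale for what a single change can do in this assay, and no direction. The expected step is a 1.1-fold higher number from compound 2 to compound 4 (0.04 log units; within the scatter), so no shift beyond the scatter is expected, and the range is kept wide on both sides. For compound 4 the estimated value is 22000 nM, with an expected range of 7000 nM to 80000 nM.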

Compound 4, half-maximal cytotoxic concentration: 21200 nM
Compound 4: the middle estimate sits 1.0-fold (0.02 log units) above what was measured; low and high end bracket the measured number.
By their numbers in this assay, from the lowest: compounds 2 and 4 (each within the scatter of the next); then compound 1. At a limit, above all of these: compound 3.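

At the aromatic carbon ortho to a large group, 1H-pyrrol-1-yl in place of fluoro gives a 1.0-fold higher number from compound 2 to compound 4 (0.02 log units; within the scatter) in this assay. Among these compounds, this is the first reading at this position, and it shows that a five-membered aromatic ring with 1 hetero atom can replace a single fluorine here with no shift beyond the scatter. Neither compound 2 nor compound 4 sits at the limit of the read-out, so this step can be read as a number: the limit of > 100000 nM in this assay, at which 1 of the 4 values shown sits.

Compound 3 gives only a limit, > 100000 nM, and says nothing about this change. Still open, from the compounds shown here alone, is whether an amine, a carboxylic acid or a nitrile on the same aromatic carbon would also stay within the scatter of compound 2, since two substituents alone cannot establish a trend at this position.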